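This account rests on a few compounds, and the source may have more. Where it says the series, first, only, none or still open, it means among the compounds named here.

Compound 1 `CCn1c(C(=O)N[C@@H](CC(=O)OC)C(=O)OC)ccc1C(CC)(CC)c1ccc(OCS(=O)(=O)c2ccccc2)c(C)c1` gives > 50000 nM in a functional assay on MCF7 cells (Homo sapiens) for antiproliferative activity, read by MTT assay, with a stated time of 24 h (on this read-out higher numbers stand for weaker inhibition and lower numbers for stronger inhibition), which is a limit of the assay.
Compound 2 `CCn1c(C(=O)N[C@@H](CO)CCCO)ccc1C(CC)(CC)c1ccc(OCS(=O)(=O)c2ccccc2)c(C)c1` gives 29600 nM in this assay.

Among the numbers shown, compound 2 holds the only value reported as a number; the other entry is a limit (the limit of > 50000 nM in this assay, at which 1 of the 2 values shown sits). Compound 3 `CCn1c(C(=O)N[C@H](CCC(=O)O)C(=O)O)ccc1C(CC)(CC)c1ccc(OCS(=O)(=O)c2ccccc2)c(C)c1` differs from compound 2 by a group of 9 heavy atoms (5 carbon, 4 oxygen; no ring) in place of a group of 7 heavy atoms (5 carbon, 2 oxygen; no ring), on an amide-type nitrogen. For the measured compounds named here, the one measured step at the same position, an at least 1.6-fold lower number from compound 1 to compound 2 (0.22 log units; that floor lies within the scatter), has a floor within the scatter, so it gives little direction for the new change. A change of about a 1.4-fold higher number from compound 2 to compound 3 (0.13 log units; within the scatter) is therefore expected, not beyond the scatter. Compound 3 is estimated at 40000 nM, with a range from 15000 nM to 110000 nM.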

Compound 3, half-maximal inhibitory concentration: > 50000 nM
Compound 3 was reported as a limit (the forecaster's own chance of this, stated with the estimate: 45%); at least 1.2-fold (0.09 log units) between middle value and limit.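

In this assay compound 3 gives > 50000 nM, which is a limit of the assay and not a number. With 1,3-dicarboxypropyl on the amide-type nitrogen the result is an at least 1.6-fold higher number from compound 2 to compound 3 (0.22 log units; that floor lies within the scatter), so this change does not yet clearly separate the two compounds. The step between compound 1 and compound 3 cannot be read, and this position now shows more limits than numbers: the limit of > 50000 nM in this assay, at which 2 of the 3 values shown sit.

Whether a real gap lies behind these limits stays open. So does what an amine or a longer chain ending in a single hydroxyl group would give on this nitrogen.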